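Two Halogen Swaps on a Dihydropyrimidine Carboxanilide

The source may report more compounds than this note shows. Statements on the series, on what has been measured and on what is new or still open speak of the compounds shown alone.

Measured compounds:
compound 1, `CC1=C(C(=O)Nc2ccc([N+](=O)[O-])cc2)C(c2ccc(Br)cc2)N=C(SCc2ccc(Cl)cc2)N1`, giving 3.1%
compound 2, `CC1=C(C(=O)Nc2ccc([N+](=O)[O-])cc2)C(c2ccc(Br)cc2)N=C(SCc2ccc(F)cc2)N1`, giving 2.6%
compound 3, `CC1=C(C(=O)Nc2ccc([N+](=O)[O-])cc2)C(c2cccc([N+](=O)[O-])c2)N=C(SCc2ccc(Cl)cc2)N1`, giving 2.1%

All three were tested in a functional assay on the whole organism (artery, strain albino) with Rattus norvegicus as the target, with a stated time of 15 min, at a dose of 10 mg/kg by the oral route; on this read-out lower numbers stand for less inhibition and higher numbers for more inhibition at the one dose given (going by the name of the read-out). Compound 1 gives 3.1% there. Compound 2 differs from compound 1 by fluoro in place of chloro on an aromatic carbon, and the step is a number 0.5 percentage points lower from compound 1 to compound 2 (within the scatter). Compound 3 differs from compound 1 by 3-nitrophenyl in place of 4-bromophenyl on a saturated ring carbon, and that step is a number 1 percentage points lower from compound 1 to compound 3 (within the scatter). Compound 3 gives 2.1% in this assay, and compound 2 gives 2.6%; these two numbers lie within the scatter of each other, so no order between them can be claimed.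

Compound 4, `CC1=C(C(=O)Nc2ccc([N+](=O)[O-])cc2)C(c2cccc([N+](=O)[O-])c2)N=C(SCc2ccc(F)cc2)N1`, has not yet been measured. It differs from compound 3 by fluoro in place of chloro on an aromatic carbon, the same change that leads from compound 1 to compound 2, since both place lines read the same word for word. What separates the two cores is the exchange described above from compound 1 to compound 3.

For compound 4 in this assay the expected step is a number 0.1 percentage points lower from compound 3 to compound 4 (within the scatter), because the earlier step of a number 0.5 percentage points lower from compound 1 to compound 2 (within the scatter) stayed within the scatter and the value of compound 3, 2.1%, sits close to where compound 1 started. The estimate for compound 4 is 2%, with an expected range from -4% to 9%.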

Compound 4, a percentage reported as inhibition, in the whole organism at one dose (the size of the read-out at that dose, not a potency): 2.6%
Estimate against measurement, compound 4: 0.6 percentage points below; low and high end bracket the measured number.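

In this assay, fluoro in place of chloro on the core of compound 3 gives a number 0.5 percentage points higher from compound 3 to compound 4 (within the scatter), and set beside the same change on the core of compound 1, the two steps cannot be told apart: the same change on two cores in this assay, a number 0.5 percentage points lower (within the scatter) from compound 1 to compound 2 and a number 0.5 percentage points higher (within the scatter) from compound 3 to compound 4, 1 percentage points apart, within the scatter of two such steps. The exchange of 4-bromophenyl for 3-nitrophenyl, carried onto the fluoro pair, gives no change at the digits printed from compound 2 to compound 4 (within the scatter), and here too the two cores show no difference that can be claimed: the same change on two cores in this assay, a number 1 percentage points lower (within the scatter) from compound 1 to compound 3 and no change at the digits printed (within the scatter) from compound 2 to compound 4, 1 percentage points apart, within the scatter of two such steps. This agreement does not show that the effect of either change carries over from one core to the other, for every step lies within the scatter and neither change shows an effect of its own in the first place.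

The compounds shown leave open how the read-out would respond to a non-halogen group on the benzyl ring, such as a methoxy group or an amine, or to a carboxylic acid in place of the nitro group on the anilide ring. They also leave open whether the two changes would behave alike on a compound whose number in this assay stood clearly apart from these four.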